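A few compounds are considered here, and "the series" means these few. Any claim that something is new, unique, unknown or untested is made for them only; others in the source may bear on it.

Compound 3 `O=c1c(-c2cccc([N+](=O)[O-])c2)nc2ccccc2n1Cc1ccccc1` gives 9 nM in an assay on cells for activation of Cystic fibrosis transmembrane conductance regulator (Homo sapiens), read by fluorescence, with a stated time of 10 min (on this read-out higher numbers stand for an effect only at larger amounts of compound and lower numbers for an effect already at smaller amounts), and stands lowest of the two numbers shown. Compound 1 `COC(=O)c1ccc([N+](=O)[O-])c(-c2nc3ccccc3n(Cc3ccccc3)c2=O)c1`, which carries a methyl ester and a nitro group on its pendant ring, gives 9900 nM in this assay. Compound 2 `O=C(O)c1ccc([N+](=O)[O-])c(-c2nc3ccccc3n(Cc3ccccc3)c2=O)c1` reaches only a limit of this assay, > 10000 nM. The step of a number no lower from compound 1 to compound 2 (the limit leaves the size open) cannot be sized because of the limit of > 10000 nM in this assay, at which 1 of the 3 values shown sits. Compound 4 `O=c1c(-c2ccccc2[N+](=O)[O-])nc2ccccc2n1Cc1ccccc1` differs from compound 3 by 2-nitrophenyl in place of 3-nitrophenyl on an aromatic carbon. None of the measured steps moves the nitro group, so no shown step bears directly on this change, and the expectation rests on the structural change alone. Compound 4 is estimated at 60 nM, with a range from 8 nM to 1000 nM. The expected step is a 6.7-fold higher number from compound 3 to compound 4 (0.82 log units; beyond the scatter), a weakening, though with wide uncertainty.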

Compound 4, half-maximal effective concentration: 1000 nM
Compound 4: the middle estimate sits 17-fold (1.22 log units) below what was measured; the measured number falls inside the stated range.
By their numbers in this assay, from the lowest: compound 3; then compound 4; then compound 1. At a limit, above all of these: compound 2.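

Moving the nitro group alone, from 3-nitrophenyl to 2-nitrophenyl, gives a 110-fold higher number from compound 3 to compound 4 (2.05 log units; beyond the scatter) in this assay, so the place of this one group on the pendant ring matters greatly here. With 2-nitrophenyl kept, hydrogen in place of methoxycarbonyl gives a 9.9-fold lower number from compound 1 to compound 4 (1.00 log units; beyond the scatter), a real but smaller change. Hydrogen in place of carboxy gives an at least 10-fold lower number from compound 2 to compound 4 (1.00 log units; beyond the scatter), a step that rests on the limit of compound 2. The compounds shown leave open whether an amine or a nitrile in place of the nitro group of compound 3 would keep its low number.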